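Sulfonyl aryl variation on the compound 3 core

The source may report more compounds than this note shows. Statements on the series, on what has been measured and on what is new or still open speak of the compounds shown alone.

Three compounds have numbers. In an assay on isolated protein for displacement of a labelled ligand from metabotropic glutamate receptor 5 (Homo sapiens), with a stated time of 60 min, tested at 1 uM (a higher number here means more inhibition at the concentration tested (going by the name of the read-out), a lower number less inhibition), compound 1 `COc1ccc2ncc(S(=O)(=O)c3ccc(OC)c(Cl)c3)c(N3CCC(C)CC3)c2c1` gives 21%, compound 2 `CC1CCN(c2c(S(=O)(=O)c3ccc(F)cc3)cnc3ccc(F)cc23)CC1` gives 87%, and compound 3 `COc1ccc2ncc(S(=O)(=O)c3cc(F)cc(F)c3)c(N3CCC(C)CC3)c2c1` gives 30%. Compound 3 stands second of the three: its nearest neighbour is compound 1, a number 9 percentage points higher from compound 1 to compound 3 (within the scatter), while compound 2 lies well beyond the scatter above it.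

Compound 4 `COc1ccc2ncc(S(=O)(=O)c3ccc(F)cc3)c(N3CCC(C)CC3)c2c1` is compound 3 with 4-fluorophenyl in place of 3,5-difluorophenyl on a sulfonyl sulfur. Among the measured compounds shown here, no measured step changes only the 4-fluorophenyl against the 3,5-difluorophenyl, so the single-point step at the sulfonyl sulfur that is known, from compound 1 to compound 3, is the only guide, and it stayed within the scatter. Compound 2 carries the same 4-fluorophenyl as compound 4 but on a different core, so its high number shows only what that pairing gave there. A modest upward step is therefore expected, a number 15 percentage points higher from compound 3 to compound 4 (beyond the scatter), with wide uncertainty. For compound 4 the estimate in this assay is 45%, within 20% to 80%.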

Compound 4, a percentage reported as inhibition, at one concentration (the size of the read-out at that concentration, not a potency): 27%
Estimate against measurement, compound 4: 18 percentage points above; the measured number falls inside the stated range.
By their numbers in this assay, from the lowest: compounds 1, 4 and 3 (each within the scatter of the next); then compound 2.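

In this assay 4-fluorophenyl in place of 3,5-difluorophenyl on a sulfonyl sulfur gives a number 3 percentage points lower from compound 3 to compound 4 (within the scatter) and 4-fluorophenyl in place of 3-chloro-4-methoxyphenyl gives a number 6 percentage points higher from compound 1 to compound 4 (within the scatter) so these three aryl groups do not separate on the shared core. Methoxy in place of fluoro on an aromatic carbon, with 4-fluorophenyl held constant, gives a number 60 percentage points lower from compound 2 to compound 4 (beyond the scatter) and is the one large step here, so the high number of compound 2 does not travel with 4-fluorophenyl alone. Nothing available here accounts for the size of that step.

On these data alone, whether the sulfonyl aryl group responds on this core to a substituent of another kind, such as a carboxylic acid or an aminomethyl group, remains open. Also open, as far as these compounds go, is whether 3,5-difluorophenyl or 3-chloro-4-methoxyphenyl would hold a high number on the core of compound 2.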